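The source may report more compounds than this note shows. Statements on the series, on what has been measured and on what is new or still open speak of the compounds shown alone.

In an ADME assay on microsomes from liver (Homo sapiens) for metabolic stability, read by LC-MS, tested at 1 uM (on this read-out lower numbers stand for a less stable compound and higher numbers for a more stable compound), compound 2 `CS(=O)(=O)NC(=O)/C=C/c1cn(-c2ccc(Cl)cc2)nc1-c1ccncc1` gives 88% and compound 1 `CS(=O)(=O)NC(=O)CCc1cn(-c2ccc(Br)cc2)nc1-c1ccc(Cl)cc1` gives 90%, so these two sit within the usual scatter of each other. Compound 3 `CS(=O)(=O)NC(=O)C1CC1c1cn(-c2ccc(Cl)cc2)nc1-c1ccncc1` reads > 99%, which is a limit of the assay and not a number. Compound 4 `CS(=O)(=O)NC(=O)OCc1cn(-c2ccc(Cl)cc2)nc1-c1ccncc1` keeps the rest of compound 2 and changes one chain on an aromatic carbon: (((methylsulfonyl)carbamoyl)oxy)methyl in place of 2-((methylsulfonyl)carbamoyl)ethenyl on an aromatic carbon. Going by the values given here, no measured pair shows such a swap, so the expectation leans on compound 2 at 88%. The expected step of a number 3 percentage points lower from compound 2 to compound 4 (within the scatter) in this assay is small, slightly downward and within the scatter. For compound 4 the estimated value is 85%, with an expected range from 68% to 97%.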

Compound 4, percent of the compound remaining in the Homo sapiens assay: 97%
Beside the measured number, compound 4's estimate is 12 percentage points below it, within the range that was stated.
By their numbers in the Homo sapiens assay, from the lowest: compounds 2, 1 and 4 (each within the scatter of the next). At a limit, above all of these: compound 3.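

In the Homo sapiens assay, putting (((methylsulfonyl)carbamoyl)oxy)methyl in place of 2-((methylsulfonyl)carbamoyl)ethenyl on this aromatic carbon gives a number 9 percentage points higher from compound 2 to compound 4 (within the scatter). This is the first one-place change shown at this position, and its effect on stability cannot be told apart from the scatter. In a physicochemical assay for lipophilicity, read by HPLC, at pH 7.4 (on this read-out higher numbers stand for higher lipophilicity and lower numbers for lower lipophilicity), however, compound 2 gives 0.98 and compound 4 gives 2.73, and the same swap clearly separates the two compounds: the measured distribution coefficient of compound 2, 0.98, and of compound 4, 2.73, a number 1.75 log units higher (beyond the scatter)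

As far as these compounds go, it remains open whether a carboxylic acid or a longer chain on this carbon would give a similar stability reading. It also remains open which part of the swap accounts for the lipophilicity step.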